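The source may report more compounds than this note shows. Statements on the series, on what has been measured and on what is new or still open speak of the compounds shown alone.

Compound 1 `O=C(O)Cc1sc(C(c2ccc(F)cc2)c2ccc(F)cc2)nc1-c1ccnc(F)c1`: 80%
Compound 2 `O=C(O)Cc1sc(C(c2ccc(F)cc2)c2ccc(F)cc2)nc1-c1ccnc(N2CCC2)c1`: 80%
Compound 3 `O=C(O)Cc1sc(C(c2ccc(F)cc2)c2ccc(F)cc2)nc1-c1ccncc1`: 80%

In an in vitro functional assay on HEK285-7 cells for antagonist activity at prostaglandin D2 receptor 2 (Homo sapiens), read by BRET and beta-arrestin recruitment (on this read-out higher numbers stand for larger maximal responses and lower numbers for smaller maximal responses), compound 3 stands level with compounds 1 and 2. no change at the digits printed from compound 1 to compound 3 (within the scatter), and no change at the digits printed from compound 2 to compound 3 (within the scatter). The third pair shows the same picture, no change at the digits printed from compound 1 to compound 2 (within the scatter), so every measured step in this small set lies within the scatter.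

Compound 4 `Cc1cc(-c2nc(C(c3ccc(F)cc3)c3ccc(F)cc3)sc2CC(=O)O)cnc1N` is the compound not yet measured. Its difference from compound 3 is 6-amino-5-methylpyridin-3-yl in place of pyridin-4-yl on an aromatic carbon. The three measured steps all touch the same region of the shared core as this change, but each of them swaps only one substituent on the pyridinyl group, whereas here the whole pyridin-4-yl is exchanged for 6-amino-5-methylpyridin-3-yl. They therefore bear on it only loosely; what they do show is that this region has tolerated every change tried without moving the maximal response. For compound 4 the step of no change at the digits printed from compound 3 to compound 4 (within the scatter) is expected to remain within the scatter, with no direction favoured. Compound 4 is estimated at 80%, in the range 65% to 92%.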

Compound 4, largest response reached (reported as efficacy), in percent of the reference or control that the assay uses: 80%
Estimate against measurement, compound 4: no gap at the digits printed, and the stated range covers the measured number.
By their numbers in this assay, from the lowest: compounds 1, 2, 3 and 4 (each within the scatter of the next).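

In this assay, exchanging the whole ring rather than one substituent on it left the maximal response in place, with no change at the digits printed from compound 3 to compound 4 (within the scatter), so this carbon of the shared core accepts 6-amino-5-methylpyridin-3-yl as well as pyridin-4-yl. The comparisons with the substituted rings read the same way, with no change at the digits printed from compound 2 to compound 4 (within the scatter) and no change at the digits printed from compound 1 to compound 4 (within the scatter), which extends the flat picture to a ring carrying both an amine and a methyl group. No measurement at hand explains why the response stays level across these groups.

Going by these compounds, whether a plain phenyl or a morpholine on this carbon would shift the response remains open, since all four compounds read level. On these data alone, all four also carry the same carboxymethyl group, so the effect of an amide or a longer acid chain there is unknown.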